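The source may report more compounds than this note shows. Statements on the series, on what has been measured and on what is new or still open speak of the compounds shown alone.

The compounds share the core of compound 3, `CCOC(=O)c1oc2ccc(N(Cc3ccc(Br)cc3)S(=O)(=O)c3ccc(Br)cc3)cc2c1C`. For the measured compounds named here, in a functional assay on HCT-116 cells (Homo sapiens) for inhibition, read by MTT assay, with a stated time of 72 h (a lower number here means a stronger inhibitor, a higher number a weaker inhibitor), compound 3 gives 5220 nM, the only actual number among the three measured compounds. For compound 1, `CCOC(=O)c1oc2ccc(NS(=O)(=O)c3ccc(Br)cc3)cc2c1C`, the result is a limit of the assay, > 40000 nM. For compound 2, `CCOC(=O)c1oc2ccc(N(Cc3ccccc3)S(=O)(=O)c3ccc(OC)cc3)cc2c1C`, the result is likewise a limit, > 40000 nM. Going by the values given here, the one step that could be measured, an at least 7.6-fold lower number from compound 1 to compound 3 (0.88 log units; beyond the scatter), concerns a 4-bromobenzyl group on the sulfonamide nitrogen and lies beyond the scatter. Its size is known only as a lower bound, since compound 1 sits at the limit of > 40000 nM in this assay, at which 2 of the 3 values shown sit. Compound 4, `Cc1c(C(=O)O)oc2ccc(N(Cc3ccc(Br)cc3)S(=O)(=O)c3ccc(Br)cc3)cc12`, differs from compound 3 at a different place: hydrogen in place of ethyl on an oxygen next to a carbonyl group. No measured step touches that oxygen, so none of the measured steps bears on this change, and neither its size nor its direction can be read from the numbers shown. The estimate for compound 4 in this assay is therefore a cautious 15000 nM, expected to fall between 3000 nM and 40000 nM. That expectation corresponds to a step of a 2.9-fold higher number from compound 3 to compound 4 (0.46 log units; beyond the scatter).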

Compound 4, half-maximal inhibitory concentration: > 40000 nM
Compound 4: only a limit was reported; the forecaster's own chance of this, stated with the estimate: 40%; middle value at least 2.6-fold (0.42 log units) away from the limit.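

Replacing the ethyl with hydrogen, which turns the ethoxycarbonyl into a carboxy group, gives the first measured result for a change at this oxygen: in this assay, the step is an at least 7.6-fold higher number from compound 3 to compound 4 (0.88 log units; beyond the scatter). This shows that the ester end of the molecule matters as well as the sulfonamide nitrogen, as the ethyl ester of compound 3 gives a measurable number and the carboxy group of compound 4 does not. The step is only a lower bound, and the true gap may be larger, since the value of compound 4 is a limit of the assay: the limit of > 40000 nM in this assay, at which 3 of the 4 values shown sit.

From the compounds shown here alone, whether a methyl or a longer chain on this oxygen would keep the number of compound 3 remains open, as does the outcome of an amide in place of the ester. The compounds shown also cannot tell why removing the ethyl raises the number.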